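A few compounds are considered here, and "the series" means these few. Any claim that something is new, unique, unknown or untested is made for them only; others in the source may bear on it.

Four esters share one core and differ only in the saturated chain on the ester oxygen. Compound 1 `CCCCCCCCCOC(=O)CCC(=O)N1CCN(CCCOc2cc3c(Nc4ccc(F)c(Cl)c4)ncnc3cc2OC)CC1` was tested in a functional assay on A549 cells (Homo sapiens) for cytotoxicity, read by MTT assay, with a stated time of 24 h, tested at 60 uM (on this read-out higher numbers stand for a weaker effect at the one concentration tested and lower numbers for a stronger effect), and gave 10.3%. Compound 2 `CCCCCCCCCCOC(=O)CCC(=O)N1CCN(CCCOc2cc3c(Nc4ccc(F)c(Cl)c4)ncnc3cc2OC)CC1` differs from compound 1 by methyl in place of hydrogen on a saturated chain carbon, nine bonds along the chain from an oxygen next to a carbonyl group; in this assay compound 2 gave 3.9%, a step of a number 6.4 percentage points lower from compound 1 to compound 2 (within the scatter). Compound 3 `CCCCCCCCCCCCCCCCCOC(=O)CCC(=O)N1CCN(CCCOc2cc3c(Nc4ccc(F)c(Cl)c4)ncnc3cc2OC)CC1` differs from compound 1 by octyl in place of hydrogen on a saturated chain carbon, nine bonds along the chain from an oxygen next to a carbonyl group; in this assay compound 3 gave 84.1%, so that a number 73.8 percentage points higher from compound 1 to compound 3 (beyond the scatter) and a number 80.2 percentage points higher from compound 2 to compound 3 (beyond the scatter) are both large. Compound 4 `CCCCCCCCCCCCCCCCCCOC(=O)CCC(=O)N1CCN(CCCOc2cc3c(Nc4ccc(F)c(Cl)c4)ncnc3cc2OC)CC1` has not been measured; it differs from compound 3 by methyl in place of hydrogen on a saturated chain carbon, ten or more bonds along the chain from an oxygen next to a carbonyl group. This is the same kind of change as the one separating compound 1 and compound 2, but not the same: the carbon that carries the new methyl lies at a different distance along the chain from an oxygen next to a carbonyl group in the two pairs, as the two differences described above show. Because a number 6.4 percentage points lower from compound 1 to compound 2 (within the scatter) stayed within the scatter, a similarly small step is expected for compound 4, namely a number 1.9 percentage points higher from compound 3 to compound 4 (within the scatter). Compound 4 is therefore estimated at 86%, with a likely range from 72% to 98%.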

Compound 4, a percentage reported as activity, at one concentration (the size of the read-out at that concentration, not a potency): 87.2%
The estimate for compound 4 lay 1.2 percentage points below the measured number, and the stated range covers the measured number.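

In this assay the added methyl again changed little, with a number 3.1 percentage points higher from compound 3 to compound 4 (within the scatter), and the step on the longer chain agrees with the one on the shorter chain: the same change on two cores in this assay, a number 6.4 percentage points lower (within the scatter) from compound 1 to compound 2 and a number 3.1 percentage points higher (within the scatter) from compound 3 to compound 4, 9.5 percentage points apart, within the scatter of two such steps

The long chain extensions also carried over, with a number 83.3 percentage points higher from compound 2 to compound 4 (beyond the scatter) and a number 76.9 percentage points higher from compound 1 to compound 4 (beyond the scatter) both large, and the first of these agrees with the earlier extension: the same change on two cores in this assay, a number 73.8 percentage points higher (beyond the scatter) from compound 1 to compound 3 and a number 83.3 percentage points higher (beyond the scatter) from compound 2 to compound 4, 9.5 percentage points apart, within the scatter of two such steps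

This shows agreement only among these four esters, which share one core and differ only in the chain, and since both methyl steps lie within the scatter, there is no clear methyl effect to carry over, so nothing can be said about how the change would behave on a different core.

The compounds shown leave open at which chain length between those of compound 2 and compound 3 the large change in the read-out sets in. They also leave open whether a branched chain, or a carboxylic acid or an amine at the chain end, would follow the same steps.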